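Growth inhibition notes: compound 1 to compound 4

The compounds below may be only part of what the source reports. "The series", "measured", "known", "first", "only" and "open" are said of these compounds alone.

Values in a functional assay on DU-145 cells (Homo sapiens) for inhibition, read by trypan blue exclusion, with a stated time of 96 h; a lower number here means a stronger inhibitor of growth, a higher number a weaker inhibitor of growth:
Compound 1 `Cc1ccc(CS/C(=C/c2ccc(O)cc2)C(=O)c2ccc(Cl)cc2)cc1`: 10000 nM
Compound 2 `O=C(/C(=C\c1ccc(O)c([N+](=O)[O-])c1)SCc1ccc(Br)cc1)c1c(F)c(F)c(F)c(F)c1F`: 10000 nM
Compound 3 `O=C(O)c1cc(/C=C(\C(=O)c2c(F)c(F)c(F)c(F)c2F)S(=O)(=O)c2ccc(Br)cc2)ccc1O`: > 100000 nM

The entry for compound 3 is a limit of the assay, not a number. Compound 1 stands level with compound 2 at the digits shown, with no gap beyond the scatter. The next compound is compound 4 `Cc1ccc(CS/C(=C/c2ccccc2F)C(=O)c2ccc(Cl)cc2)cc1`, with 2-fluorophenyl in place of 4-hydroxyphenyl on a double-bonded chain carbon bound to a double-bonded chain carbon. Among the measured compounds shown here, no measured pair differs in one place, so nothing sizes this step directly. In this assay, no shift beyond the scatter is expected: the estimated step is a 1.3-fold lower number from compound 1 to compound 4 (0.10 log units; within the scatter). Compound 4 is estimated at 8000 nM, with an expected range of 2000 nM to 30000 nM.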

Compound 4, concentration for 50% growth inhibition: 10000 nM
The estimate for compound 4 lay 1.3-fold (0.10 log units) below the measured number, within the range that was stated.
By their numbers in this assay, from the lowest: compounds 1, 2 and 4 (each within the scatter of the next). At a limit, above all of these: compound 3.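

In this assay, among the compounds shown here, the first comparison that differs in one place shows no change at the digits printed from compound 1 to compound 4 (within the scatter). On a double-bonded chain carbon bound to a double-bonded chain carbon, 2-fluorophenyl can therefore replace 4-hydroxyphenyl, losing the hydrogen-bond donor counted for 4-hydroxyphenyl, with no shift beyond the scatter. No measured property available here bears on this result.

Still open, going by these compounds, is whether an amine or a methoxy group at this position would move the number beyond the scatter. A single step also cannot show whether this flat result holds on other parts of the core.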